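The compounds below may be only part of what the source reports. "The series", "measured", "known", "first", "only" and "open" are said of these compounds alone.

Three closely related compounds share one core and differ only in where a chloromethyl-bearing benzyl arm is attached. Compound 1 `ClCc1ccccc1Cn1cnc2c(Cl)nc(Cl)nc21`, compound 2 `ClCc1ccc(Cn2cnc3nc(Cl)nc(Cl)c32)cc1` and compound 3 `ClCc1cccc(Cn2cnc3nc(Cl)nc(Cl)c32)c1` were all tested in a functional assay on NCI-H23 cells (Homo sapiens) for cytotoxicity, read by sulforhodamine B assay, with a stated time of 48 h; a lower number here means a stronger inhibitor of growth, a higher number a weaker inhibitor of growth. In this assay compound 1 gives 1510 nM, compound 2 gives 2340 nM, and compound 3 gives 1540 nM. The number for compound 2 sits alongside those of compound 1 and compound 3: its gaps to both lie within the usual scatter of repeated measurements, so these three cannot be told apart on the numbers shown.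

Compound 4 `ClCc1ccc(Cn2cnc3ncnc(Cl)c32)cc1` has not yet been measured. It differs from compound 2 by hydrogen in place of chloro on an aromatic carbon, between two ring nitrogen atoms of the core. No measured pair here shows what removing one such chloro does, so there is no shown step to lean on. The step of a 1.7-fold higher number from compound 2 to compound 4 (0.23 log units; within the scatter) is expected to be a modest loss of potency, close to the edge of the scatter. Compound 4 is therefore estimated to give 4000 nM in this assay, with a range from 1500 nM to 12000 nM.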

Compound 4, concentration for 50% growth inhibition: 15800 nM
Compound 4: the middle estimate sits 4.0-fold (0.60 log units) below what was measured, outside the stated range (above it).
By their numbers in this assay, from the lowest: compounds 1, 3 and 2 (each within the scatter of the next); then compound 4.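

The earlier compounds shown here differ only in where the chloromethyl-bearing benzyl arm is attached, and all of them carry both chloro groups on the shared core, so they could say nothing about either chloro. Here, in this assay, putting hydrogen in place of the chloro on the aromatic carbon between two ring nitrogen atoms gives a 6.8-fold higher number from compound 2 to compound 4 (0.83 log units; beyond the scatter), which makes compound 4 the weaker inhibitor of growth, while the remaining chloro stays on the core. So this single chlorine atom carries a gap that lies beyond the scatter, unlike the gaps among compound 1, compound 2 and compound 3, and nothing available here explains why it counts for so much.

As far as these compounds go, it remains open whether an amine, a methoxy group or a fluoro group at this position would behave like the chloro or like the hydrogen, and what taking away the other chloro on the core would do. It is also open whether the same loss would appear with the arm attached as in compound 1 or compound 3, since neither has a partner with hydrogen at this position among the compounds shown.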